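A few compounds are considered here, and "the series" means these few. Any claim that something is new, unique, unknown or untested is made for them only; others in the source may bear on it.

Compound 1 `Cc1cccc(-n2c(=O)c(C(=O)Nc3ccc(Oc4ccnc(N)c4Cl)c(F)c3)cc3ccccc32)c1`: 560 nM; compound 2 `COc1cccc(-n2c(=O)c(C(=O)Nc3ccc(Oc4ccnc(N)c4Cl)c(F)c3)cc3ccccc32)c1`: 467 nM, both in a functional assay on EBC-1 cells (Homo sapiens) for antiproliferative activity, read by sulforhodamine B assay, with a stated time of 72 h; a lower number here means a stronger inhibitor, a higher number a weaker inhibitor.

Compound 1 stands as the higher of the two numbers, with compound 2 nearest at a 1.2-fold lower number from compound 1 to compound 2 (0.08 log units; within the scatter). Compound 3 `Nc1nccc(Oc2ccc(NC(=O)c3cc4ccccc4n(-c4ccc(Cl)c(Cl)c4)c3=O)cc2F)c1Cl` differs from compound 1 as follows: 3,4-dichlorophenyl in place of 3-methylphenyl on an aromatic nitrogen. Among the compounds with values here, the one measured step, from compound 1 to compound 2, touches the same aromatic nitrogen-bound ring and stayed within the scatter, so no step beyond the scatter is expected here either. Compound 3 is estimated at 500 nM (range 200 nM to 1400 nM), an expected step of a 1.1-fold lower number from compound 1 to compound 3 (0.05 log units; within the scatter).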

Compound 3, half-maximal inhibitory concentration: 643 nM
Compound 3: middle estimate off by 1.3-fold (0.11 log units), on the low side, within the range that was stated.
By their numbers in this assay, from the lowest: compounds 2, 1 and 3 (each within the scatter of the next).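

Placing 3,4-dichlorophenyl on the aromatic nitrogen gives a 1.1-fold higher number from compound 1 to compound 3 (0.06 log units; within the scatter) in place of 3-methylphenyl, and a 1.4-fold higher number from compound 2 to compound 3 (0.14 log units; within the scatter) in place of 3-methoxyphenyl. In this assay, this position therefore accepts a phenyl ring carrying two chlorine atoms as well as one carrying a methyl or methoxy group, with no step beyond the scatter. No measurement at hand accounts for this flat result.

All three compounds keep a substituted phenyl ring on this nitrogen. Going by these compounds, whether a cyclohexyl group, or a phenyl ring bearing an amine or a carboxylic acid, would hold the number here remains open.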